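This account rests on a few compounds, and the source may have more. Where it says the series, first, only, none or still open, it means among the compounds named here.

Working notes on the series. Compound 1 `COc1ncnc2c1c(I)cn2[C@@H]1O[C@H](CO)[C@@H](O)[C@H]1O` and compound 2 `CNc1ncnc2c1c(-c1ccsc1)cn2[C@@H]1O[C@H](CO)[C@@H](O)[C@H]1O` share the same core and differ in two groups. In a functional assay on HCT-116 cells (Homo sapiens), read by MTT assay, with a stated time of 72 h (on this read-out higher numbers stand for weaker inhibition and lower numbers for stronger inhibition), compound 1 returns only a limit of the assay, > 20000 nM. In this assay compound 2 likewise returns only a limit, > 20000 nM. Going by the values given here, compound 2 thus stands at the limit, and the one further value shown, that of compound 1, is a limit as well; both sit at the limit of > 20000 nM in this assay, at which 2 of the 2 values shown sit, so no measured step between them can be sized. Compound 3 `COc1ncnc2c1c(-c1ccsc1)cn2[C@@H]1O[C@H](CO)[C@@H](O)[C@H]1O` is still to be measured. It differs from compound 2 by methoxy in place of methylamino on an aromatic carbon. Compound 1 already carries the methoxy group and gives only a limit, as does compound 2 with methylamino, so no step beyond the scatter is expected in this assay. The step that the limit leaves unreadable from compound 2 to compound 3 is estimated as essentially none. Compound 3 is expected at 30000 nM, within a range from 10000 nM to 90000 nM, most likely reported again only as a limit.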

Compound 3, half-maximal inhibitory concentration: 120 nM
Compound 3: the middle estimate sits 250-fold (2.40 log units) above what was measured; the whole stated range lies above it.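

In this assay, with thiophen-3-yl held in place, methoxy in place of methylamino on the aromatic carbon next to the ring nitrogen gives an at least 160-fold lower number from compound 2 to compound 3 (2.22 log units; beyond the scatter). With methoxy held in place, thiophen-3-yl in place of iodo on an aromatic carbon gives an at least 160-fold lower number from compound 1 to compound 3 (2.22 log units; beyond the scatter). Neither change alone could be judged from the earlier compounds; among the three compounds shown, only the one carrying both methoxy and thiophen-3-yl leaves the limit of the assay, so this position is sensitive to the methylamino-to-methoxy change when thiophen-3-yl is present.

On these data alone, both steps start from a limit, so their full size cannot be read: the limit of > 20000 nM in this assay, at which 2 of the 3 values shown sit. It remains open whether ethoxy or a plain amino group at this place, or phenyl in place of thiophen-3-yl, would keep a number like that of compound 3.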